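Ring contraction and amide swap on the aromatic amine nitrogen

This account rests on a few compounds, and the source may have more. Where it says the series, first, only, none or still open, it means among the compounds named here.

Of the compounds shown here, three built on one shared core have so far been measured in an assay on isolated protein for inhibition of protein kinase C delta type (Homo sapiens), read by TR-FRET, with a stated time of 2 h; a higher number here means a weaker inhibitor, a lower number a stronger inhibitor. Compound 1 `CO[C@H]1CC[C@@H](CNc2cc(NCc3cnccc3C(F)(F)F)ncc2C#N)CC1` gives 5000 nM. Compound 2 `CC1(C)C[C@H](Nc2cc(NCc3cnccc3C(F)(F)F)ncc2C#N)CC[C@H]1O` gives 2200 nM, and compound 3 `CC1(C)C[C@@H](Nc2cc(NCc3cnccc3C(F)(F)F)ncc2C#N)CC[C@H]1O` gives 2400 nM. Compound 3 thus holds the second highest of the three numbers: the gap a 1.1-fold higher number from compound 2 to compound 3 (0.04 log units; within the scatter) is within the scatter, which is consistent with the fact that compounds 2 and 3 differ only in the configuration as drawn, whereas the step of a 2.1-fold lower number from compound 1 to compound 3 (0.32 log units; beyond the scatter) lies beyond it.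

Compound 4 `CC1(C)[C@@H](Nc2cc(NCc3cnccc3C(F)(F)F)ncc2C#N)C[C@H]1C(N)=O` awaits measurement. It differs from compound 3 in a single place: 3-carbamoyl-2,2-dimethylcyclobutyl in place of 4-hydroxy-3,3-dimethylcyclohexyl on a nitrogen on an aromatic ring. The ring that enters is four-membered where the one that leaves is six-membered, a carboxamide replaces a hydroxyl, and the group that enters carries the same tallies of donors and acceptors as the one that leaves, as the counted difference shows.

Going by the values given here, the only measured changes at this nitrogen are a 2.3-fold lower number from compound 1 to compound 2 (0.36 log units; beyond the scatter) and a 2.1-fold lower number from compound 1 to compound 3 (0.32 log units; beyond the scatter), both modest, while a 1.1-fold higher number from compound 2 to compound 3 (0.04 log units; within the scatter) stays within the scatter. Since the groups exchanged here are of similar size, the step of a 1.0-fold higher number from compound 3 to compound 4 (0.02 log units; within the scatter) is expected to be small, with either direction possible. Compound 4 is therefore estimated at 2500 nM, with a range of 800 nM to 8000 nM.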

Compound 4, half-maximal inhibitory concentration: 4500 nM
Estimate against measurement, compound 4: 1.8-fold (0.26 log units) below, and the stated range covers the measured number.
By their numbers in this assay, from the lowest: compounds 2, 3, 4 and 1 (each within the scatter of the next, the first and the last beyond it).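

At this nitrogen, the six-membered ring of 4-hydroxy-3,3-dimethylcyclohexyl gives way to the four-membered ring of 3-carbamoyl-2,2-dimethylcyclobutyl, and a carboxamide replaces the hydroxyl, yet the step of a 1.9-fold higher number from compound 3 to compound 4 (0.27 log units; within the scatter) stays within the scatter, so this large change of ring and group leaves the number essentially in place. Going by these compounds alone, measured from compound 2, which carries the same 4-hydroxy-3,3-dimethylcyclohexyl group in the other drawn configuration, the same exchange gives a 2.0-fold higher number from compound 2 to compound 4 (0.31 log units; beyond the scatter) and is the first modest step at this position in which the number rises. The modest advantage that compounds 2 and 3 showed on replacing (4-methoxycyclohexyl)methyl is not clearly retained, as the step of a 1.1-fold lower number from compound 1 to compound 4 (0.05 log units; within the scatter) lies within the scatter and leaves 3-carbamoyl-2,2-dimethylcyclobutyl not separated from that group.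

The ring size and the carboxamide change together in compound 4, so the compounds shown cannot tell their contributions apart, and a 4-carbamoyl-3,3-dimethylcyclohexyl group would be the one to separate them. Nothing available here bears on why the numbers for compound 4 fall where they do.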